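Removing a methyl from an aromatic nitrogen: what compound 4 may give

The source may report more compounds than this note shows. Statements on the series, on what has been measured and on what is new or still open speak of the compounds shown alone.

Of the compounds shown here, three have been measured in a functional assay on MV4-11 cells (Homo sapiens) for antiproliferative activity, with a stated time of 6 days, tested at 6.25 uM; on this read-out lower numbers stand for a weaker effect and higher numbers for a stronger effect at the one concentration tested. Compound 1 `CNC(=O)N1CCCc2ccc(NC(=O)c3ccc(-c4cc[nH]n4)cc3)cc21` gives 99.1%, compound 2 `CNC(=O)N1CCCc2ccc(NC(=O)c3ccc(-c4ccn(C)n4)cc3)cc21` gives 97%, and compound 3 `CNC(=O)N1CCCc2ccc(NC(=O)c3cccc(-c4cnn(C)c4)c3)cc21` gives 93.5%. Compound 1 differs from compound 2 by hydrogen in place of methyl on an aromatic nitrogen; the step this change made is a number 2.1 percentage points higher from compound 2 to compound 1 (within the scatter). Compound 3 and compound 2 are built from the same atoms joined differently; the difference between the two cores is not broken down here.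

Compound 4 `CNC(=O)N1CCCc2ccc(NC(=O)c3cccc(-c4cn[nH]c4)c3)cc21` is not yet measured. It differs from compound 3 by hydrogen in place of methyl on an aromatic nitrogen. The place is the same in its wording, but the groups cut one bond further out read 1-methyl-1H-pyrazol-3-yl to 1H-pyrazol-3-yl in the first pair and 1-methyl-1H-pyrazol-4-yl to 1H-pyrazol-4-yl in the second, so this is the same kind of change, not the same change.

Because the earlier step was a number 2.1 percentage points higher from compound 2 to compound 1 (within the scatter), compound 4 is expected to move by a number 1.5 percentage points higher from compound 3 to compound 4 (within the scatter) in this assay. Compound 4 is therefore estimated at 95%, expected between 87% and 100%.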

Compound 4, a percentage reported as inhibition, at one concentration (the size of the read-out at that concentration, not a potency): 77.7%
Compound 4: middle estimate off by 17.3 percentage points, on the high side, and the stated range ends above it.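

In this assay, hydrogen in place of methyl on an aromatic nitrogen gave a number 15.8 percentage points lower from compound 3 to compound 4 (beyond the scatter), and this does not match the earlier result on the other core: the same change on two cores in this assay, a number 2.1 percentage points higher (within the scatter) from compound 2 to compound 1 and a number 15.8 percentage points lower (beyond the scatter) from compound 3 to compound 4, 17.9 percentage points apart, beyond the scatter of two such steps. The effect of this change therefore did not carry from the core of compound 2 to the core of compound 3, and a step read on one of these cores is a poor guide to the other. Among the compounds shown here, this rests on only two pairs at a single concentration, so it shows neither why the steps differ nor which feature separating the two cores matters, and it gives no measure of potency.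

The compounds shown leave open how an ethyl group or a longer chain on the same nitrogen would read on either core. They also leave open whether the lower number of compound 4 is particular to the 1H-pyrazol-4-yl group or would recur with another ring, such as a pyridine, in its place.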